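This account rests on a few compounds, and the source may have more. Where it says the series, first, only, none or still open, it means among the compounds named here.

For the measured compounds named here, in an ADME assay on liver for metabolic stability, with Liver microsome (Homo sapiens) as the target, read by LC-MS, using microsomes (on this read-out lower numbers stand for slow clearance and higher numbers for fast clearance), compound 1 `CC(C)(C)C[C@@H](O)C(=O)N1[C@H](C(=O)NCc2cc(Cl)ccc2-n2cnnn2)C[C@@H]2C[C@@H]21` gives 40 mL.min-1.g-1 and compound 2 `O=C(NCc1cc(Cl)ccc1-n1cnnn1)[C@@H]1C[C@@H]2C[C@@H]2N1C(=O)[C@H](O)Cc1ccccn1` gives 17 mL.min-1.g-1, so compound 2 holds the lower of the only two numbers so far. The next compound, compound 3 `COC(C)(C)[C@@H](O)C(=O)N1[C@H](C(=O)NCc2cc(Cl)ccc2-n2cnnn2)C[C@@H]2C[C@@H]21`, keeps the shared core and changes one group: 1-methoxy-1-methylethyl in place of (pyridin-2-yl)methyl on a saturated chain carbon bound to a carbonyl carbon and an oxygen on a saturated carbon. Going by the values given here, only one measured step bears on this: a 2.4-fold lower number from compound 1 to compound 2 (0.37 log units; beyond the scatter), a modest change beyond the scatter that came with pyridin-2-yl in place of tert-butyl. Like the tert-butyl of compound 1 at 40 mL.min-1.g-1, the entering 1-methoxy-1-methylethyl has no ring, but it does hold an oxygen, so the match is only partial and just part of that step is expected to reverse. A small upward step is therefore expected in this assay, estimated as a 1.5-fold higher number from compound 2 to compound 3 (0.18 log units; within the scatter). For compound 3 the expected value is 26 mL.min-1.g-1, with an estimated range of 13 mL.min-1.g-1 to 50 mL.min-1.g-1.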

Compound 3, intrinsic clearance in microsomes: 40 mL.min-1.g-1
Compound 3: middle estimate off by 1.5-fold (0.19 log units), on the low side; the range from low to high includes it.
By their numbers in this assay, from the lowest: compound 2; then compounds 1 and 3 (each within the scatter of the next).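

In this assay, putting 1-methoxy-1-methylethyl in place of (pyridin-2-yl)methyl gives a 2.4-fold higher number from compound 2 to compound 3 (0.37 log units; beyond the scatter) and so undoes the earlier drop, while putting it in place of neopentyl gives no change at the digits printed from compound 1 to compound 3 (within the scatter) and shows no difference. At this position, then, an oxygen in a ringless group leaves the number where the all-carbon neopentyl had it, and of these three compounds only compound 2, the one with a ring, stands apart. Nothing available explains why the numbers fall this way.

As far as these compounds go, whether the lower number of compound 2 goes with the ring itself or with its nitrogen stays open, and a phenyl group on the same chain carbon would bear on that. From the compounds shown here alone, how an amine or a carboxylic acid would read there also remains unknown.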